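This account rests on a few compounds, and the source may have more. Where it says the series, first, only, none or still open, it means among the compounds named here.

Measured compounds:
- compound 1 `COc1ccc(/C=N/NC(=S)N/N=C2\C(=O)Nc3ccc(C)cc32)cc1O`, 2730 nM in a functional assay on HeLa cells (Homo sapiens) for inhibition, read by MTT assay; a higher number here means a weaker inhibitor, a lower number a stronger inhibitor
- compound 2 `Cc1ccc(O)c(/C=N/NC(=S)N/N=C2\C(=O)Nc3ccc(Br)cc32)c1`, at the limit > 50000 nM in this assay
- compound 3 `Cc1ccc(O)c(/C=N/NC(=S)N/N=C2\C(=O)Nc3ccc(C)cc32)c1`, at the limit > 50000 nM in this assay

Compound 3 stands at the upper end of what the numbers show: in this assay it is reported only as a limit, not a number, and that limit is shared with compound 2 (the limit of > 50000 nM in this assay, at which 2 of the 3 values shown sit). Compound 1, which carries 3-hydroxy-4-methoxyphenyl on the carbon with a double bond to nitrogen, is the only one of the three with a measured number, and the step of an at least 18-fold higher number from compound 1 to compound 3 (1.26 log units; beyond the scatter) is large. The step that the two limits leave unreadable from compound 2 to compound 3 cannot be read from its two limits.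

Compound 4 `Cc1ccc2c(c1)/C(=N/NC(=S)N/N=C/c1ccccc1Br)C(=O)N2` is the next step from compound 3: 2-bromophenyl in place of 2-hydroxy-5-methylphenyl on a carbon with a double bond to nitrogen. Among the compounds with values here, no measured pair shows this exact change. Within the data shown here, what bears on it is the one readable step on that carbon, an at least 18-fold higher number from compound 1 to compound 3 (1.26 log units; beyond the scatter), which shows that the aryl group there moves the value a great deal; 2-hydroxy-5-methylphenyl accompanies both limits, and replacing it with 2-bromophenyl is expected to bring the number back down, though the size is uncertain. Compound 4 is estimated at 12000 nM, within 2500 nM to 50000 nM, meaning an expected step of an at least 4.1-fold lower number from compound 3 to compound 4 (0.61 log units; beyond the scatter).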

Compound 4, half-maximal inhibitory concentration: > 50000 nM
Compound 4: no number, only a limit; the forecaster's own chance of this, stated with the estimate: 35%; middle value at least 4.1-fold (0.61 log units) from the limit.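

In this assay compound 4 is reported only as a limit, > 50000 nM, so 2-bromophenyl in place of 2-hydroxy-5-methylphenyl gave no measured number here. Within the data shown here, the step between compound 3 and compound 4 cannot be read, since both ends are limits, but a second, different aryl group on the carbon with a double bond to nitrogen now stands far from the one measured compound, with an at least 18-fold higher number from compound 1 to compound 4 (1.26 log units; beyond the scatter). Among the compounds shown, 3-hydroxy-4-methoxyphenyl is therefore the only group at this position that goes with a number, and the limit has become the common result: the limit of > 50000 nM in this assay, at which 3 of the 4 values shown sit.

The compounds shown leave open whether 2-bromophenyl and 2-hydroxy-5-methylphenyl differ at all, and how much of the value of compound 1 rests on its hydroxy group and how much on its methoxy group. They also do not tell how a phenyl carrying only a methoxy group, or an amine in place of the hydroxy group of compound 1, would read in this assay.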